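A few compounds are considered here, and "the series" means these few. Any claim that something is new, unique, unknown or untested is made for them only; others in the source may bear on it.

For the measured compounds named here, in an ADME assay on Vero cells (Chlorocebus sabaeus) for cytotoxicity, read by MTT assay (a higher number here means that more compound is tolerated, a lower number that less compound is tolerated), compound 3 `Cn1nc(C(F)(F)F)cc1C(=O)Nc1ccc(S(=O)(=O)n2ccc3ccccc32)cc1` gives 13000 nM, the lowest number so far. Compound 1 `Cn1nc(C(F)(F)F)cc1C(=O)Nc1ccc(S(=O)(=O)N2CCC[C@H]2C(=O)OC(=O)c2ccccc2)cc1` gives 100000 nM. Compound 2 `Cn1nc(C(F)(F)F)cc1C(=O)Nc1ccc(S(=O)(=O)N2CCC[C@H]2C(=O)O)cc1` reads > 300000 nM, which is a limit of the assay and not a number. Compound 4 `Cn1nc(C(F)(F)F)cc1C(=O)Nc1ccc(S(=O)(=O)OC2CCCCC2)cc1` carries cyclohexyloxy in place of 1H-indol-1-yl on the sulfonyl sulfur: cyclohexyloxy in place of 1H-indol-1-yl on a sulfonyl sulfur. Of the measured steps, an at least 3.0-fold higher number from compound 1 to compound 2 (0.47 log units; beyond the scatter) was at least modest but changes another part of the molecule. The large step of an at least 23-fold lower number from compound 2 to compound 3 (1.36 log units; beyond the scatter) is the one made at this sulfur. Cyclohexyloxy, like 1H-indol-1-yl, has no net charge, so no step beyond the scatter is expected in this assay. The expected change is a 1.5-fold higher number from compound 3 to compound 4 (0.19 log units; within the scatter). Compound 4 is estimated at 20000 nM, within a range of 6000 nM to 70000 nM.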

Compound 4, half-maximal cytotoxic concentration: > 300000 nM
Compound 4 ended at the assay's limit (the forecaster's own chance of this, stated with the estimate: 5%); middle value at least 15-fold (1.17 log units) away from the limit.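

At the sulfonyl sulfur, this assay shows an at least 23-fold higher number from compound 3 to compound 4 (1.36 log units; beyond the scatter), so a group with no net charge can reach the same limit as compound 2, without a carboxy group. Compound 4 reads as a limit of the assay and not a number: the limit of > 300000 nM in this assay, at which 2 of the 4 values shown sit. The step from compound 2 to compound 4 cannot be read. Going by these compounds, it stays open whether the oxygen or the non-aromatic ring of cyclohexyloxy goes with the change. Phenoxy and cyclohexylamino on the sulfonyl sulfur would separate the two.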